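The source may hold more compounds than are shown below. What is called first, only, known or untested is meant among the compounds shown, and "the series" means these compounds.

Measured so far: compound 1 `CC(=O)O[C@@H]1OC(=O)[C@](C)(C(C)=O)[C@@H]1C`, which in a functional assay on HT-29 cells (Homo sapiens) for cytotoxicity, read by MTT assay (a lower number here means a stronger inhibitor, a higher number a weaker inhibitor), gives 5000 nM; compound 2 `CC(=O)O[C@@H]1OC(=O)[C@](Cc2ccccc2)(C(C)=O)[C@@H]1C`, which in this assay gives 40000 nM. Compound 3 `CC(=O)O[C@@H]1OC(=O)[C@](O)(C(C)=O)[C@@H]1C` gives in this assay only a limit, > 50000 nM.

Compound 3 therefore stands at the limit of > 50000 nM in this assay, at which 1 of the 3 values shown sits, with no number of its own. The step to compound 4 `CC(=O)O[C@@H]1OC(=O)[C@](Br)(C(C)=O)[C@@H]1C` is bromo in place of hydroxy on a saturated ring carbon. Two measured steps end at this hydroxy: an at least 10-fold higher number from compound 1 to compound 3 (1.00 log units; beyond the scatter) and an at least 1.2-fold higher number from compound 2 to compound 3 (0.09 log units; that floor lies within the scatter). Among the compounds with values here, no measured step introduces bromo, so its effect is unknown; the hydroxy is expected to be the weakening group because an at least 10-fold higher number from compound 1 to compound 3 (1.00 log units; beyond the scatter) shows it, and removing it is expected to recover part of that loss, an at least 2.5-fold lower number from compound 3 to compound 4 (0.39 log units; beyond the scatter). Compound 4 is thus estimated at 20000 nM, with a range from 5000 nM to 80000 nM.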

Compound 4, half-maximal inhibitory concentration: 12000 nM
Estimate against measurement, compound 4: 1.7-fold (0.22 log units) above, and the stated range covers the measured number.
By their numbers in this assay, from the lowest: compound 1; then compound 4; then compound 2. At a limit, above all of these: compound 3.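

Compound 3 remains only a limit in this assay: the limit of > 50000 nM in this assay, at which 1 of the 4 values shown sits.

Bromo on this saturated ring carbon, which brings no hydrogen-bond donor or acceptor, gives a measured value, with an at least 4.1-fold lower number from compound 3 to compound 4 (0.61 log units; beyond the scatter) and a 3.3-fold lower number from compound 2 to compound 4 (0.52 log units; beyond the scatter). Methyl still gives the lowest number here, with a 2.4-fold higher number from compound 1 to compound 4 (0.38 log units; beyond the scatter), so the groups with numbers at this carbon run methyl, bromo, benzyl.

Going by these compounds, what remains open is where an ethyl group, a chloro group or an amine would fall in that order.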